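Adding one hydroxy to compound 3

This account rests on a few compounds, and the source may have more. Where it says the series, first, only, none or still open, it means among the compounds named here.

Values measured in a physicochemical assay, read by spectrophotometry, with a stated time of 15 min (on this read-out lower numbers stand for stronger inhibition and higher numbers for weaker inhibition), are these
- compound 1 `O=C(CCc1nc2ccccc2c(=O)[nH]1)N/N=C/c1ccc(O)cc1` gives 300000000 nM
- compound 2 `COc1ccc(/C=N/NC(=O)CCCc2nc3ccccc3c(=O)[nH]2)cc1` gives 280000000 nM
- compound 3 `COc1cc(/C=N/NC(=O)CCc2nc3ccccc3c(=O)[nH]2)ccc1O` gives 290000000 nM

All three values lie within the usual scatter of one another, so compound 3 cannot be ranked against compound 1 or compound 2. On these numbers, the three compounds stand level.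

The next compound, compound 4 `COc1cc(/C=N/NC(=O)CCc2nc3ccccc3c(=O)[nH]2)cc(O)c1O`, differs from compound 3 in one place: hydroxy in place of hydrogen on an aromatic carbon. This is hydroxy in place of hydrogen on an aromatic carbon, ortho to a hydroxy group.

Going by the values given here, one measured step bears on this change. It is methoxy in place of hydrogen on an aromatic carbon, seen as a 1.0-fold lower number from compound 1 to compound 3 (0.01 log units; within the scatter) and lying within the scatter. That step brings in a different group, so it is only a loose guide. Among the compounds with values here, no measured step adds a hydroxy, and the range for compound 4 is therefore kept wide, mostly toward lower numbers.

No step beyond the scatter is expected in this assay for this change. The expected step is a 1.5-fold lower number from compound 3 to compound 4 (0.16 log units; within the scatter) and it stays small. For compound 4 the estimated value is 200000000 nM with an expected range from 50000000 nM to 320000000 nM in this measurement.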

Compound 4, half-maximal inhibitory concentration: 50000000 nM
Estimate against measurement, compound 4: 4.0-fold (0.60 log units) above; the range from low to high includes it.
By their numbers in this assay, from the lowest: compound 4; then compounds 2, 3 and 1 (each within the scatter of the next).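

In this assay there is a 5.8-fold lower number from compound 3 to compound 4 (0.76 log units; beyond the scatter) when hydroxy replaces hydrogen on the aromatic carbon ortho to a hydroxy group and meta to a methoxy group. The earlier step, a 1.0-fold lower number from compound 1 to compound 3 (0.01 log units; within the scatter) with a methoxy entering, lay within the scatter, so this is the first change shown that clearly moves the number, and it shows that one added oxygen atom at this position is enough to do so. Nothing measured here explains why this added hydroxy has that effect.

Going by these compounds, it remains open whether the gain belongs to the hydroxy itself or whether another small group on the same carbon, such as an amine or a fluorine, would give a similar step. On these data alone, it is also open whether the step depends on the neighbouring groups of compound 3, since it is seen here only with the hydroxy and methoxy groups in place and on the chain of compound 3, and a carboxylic acid at this position or a longer chain could tell more.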